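Cyano for Ethyl on a Weakly Cytotoxic Urea

The compounds below may be only part of what the source reports. "The series", "measured", "known", "first", "only" and "open" are said of these compounds alone.

Compound 1 `CCc1ccc(NC(=O)N(Cc2cc(OC)c(OC)c(OC)c2)n2cnnc2)cc1` holds the lower of two numbers recorded in a functional assay on A549 cells (Homo sapiens) for cytotoxicity, read by MTT assay, with a stated time of 48 h (a lower number here means a stronger inhibitor, a higher number a weaker inhibitor), where compound 1 gives 17200 nM. Among the measured compounds shown here, its only neighbour, compound 2 `Cc1ccsc1CN(C(=O)Nc1ccc(Cl)c(C(F)(F)F)c1)n1cnnc1`, gives 26200 nM in this assay, a gap within the scatter, so the two cannot be ordered. Compound 3 `COc1cc(CN(C(=O)Nc2ccc(C#N)cc2)n2cnnc2)cc(OC)c1OC` is compound 1 with a single change: cyano in place of ethyl on an aromatic carbon. For the measured compounds named here, no measured pair shows this change, so the data give no size for it. In this assay the expected step is a 1.2-fold higher number from compound 1 to compound 3 (0.07 log units; within the scatter), nothing beyond the scatter. Compound 3 is estimated at 20000 nM, between 7000 nM and 60000 nM.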

Compound 3, half-maximal inhibitory concentration: 20700 nM
The estimate for compound 3 lay 1.0-fold (0.01 log units) below the measured number; the measured number falls inside the stated range.
By their numbers in this assay, from the lowest: compounds 1, 3 and 2 (each within the scatter of the next).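

In this assay, among the compounds shown here, cyano in place of ethyl on this aromatic carbon gives a 1.2-fold higher number from compound 1 to compound 3 (0.08 log units; within the scatter), so this pair offers the first direct reading of a change at this position, and the two groups cannot be told apart. At this potency level, the shared core keeps its number within the scatter with either group in place. No measurement available here accounts for this result. Whether an amine, a carboxylic acid or a longer chain at this position would move the number beyond the scatter remains open, as the compounds shown compare only ethyl and cyano here.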